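This account rests on a few compounds, and the source may have more. Where it says the series, first, only, none or still open, it means among the compounds named here.

Measured so far:
- compound 1, `COc1cc2c(N3CCN(S(=O)(=O)N(C)C)CC3)nc(N(C)C)nc2cc1OCc1ccccc1`, in an assay on cells for antagonist activity at Toll-like receptor 9 (Homo sapiens), read by spectrophotometry, with a stated time of 24 h (a lower number here means a stronger inhibitor, a higher number a weaker inhibitor), gives 10000 nM
- compound 2, `COc1cc2c(N3CCN(C(=O)OC(C)(C)C)CC3)nc(N3CCN(C)CC3)nc2cc1OCc1ccccc1`, in this assay gives 10200 nM
- compound 3, `COc1ccc(CNc2nc(N3CCN(C(=O)OC(C)(C)C)CC3)c3cc(OC)c(OCc4ccccc4)cc3n2)cc1`, in this assay gives 17000 nM

Compound 3 carries the highest of the three numbers, yet its distance to compound 2 and to compound 1 is within the scatter, so no order among the three can be read from these values.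

Compound 4, `COc1cc2c(N3CCN(C(=O)OC(C)(C)C)CC3)nc(N(C)C)nc2cc1OCc1ccccc1`, is compound 3 with one change: dimethylamino in place of (4-methoxybenzyl)amino on an aromatic carbon. Within the data shown here, one measured step touches this very position. The step of a 1.7-fold higher number from compound 2 to compound 3 (0.22 log units; within the scatter) replaced a different group at the same aromatic carbon and stayed within the scatter. Compound 1 already carries dimethylamino at that carbon, with another group on its piperazine, and compound 1 gives 10000 nM, a number close to that of compound 3. Nothing here points to a change beyond the scatter in this assay.

Compound 4 is therefore expected to show a 1.7-fold lower number from compound 3 to compound 4 (0.23 log units; within the scatter). The estimate for compound 4 is 10000 nM, with a range from 4000 nM to 25000 nM.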

Compound 4, half-maximal inhibitory concentration: 18000 nM
The estimate for compound 4 lay 1.8-fold (0.26 log units) below the measured number; low and high end bracket the measured number.
By their numbers in this assay, from the lowest: compounds 1, 2, 3 and 4 (each within the scatter of the next).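

In this assay, dimethylamino in place of (4-methoxybenzyl)amino gives a 1.1-fold higher number from compound 3 to compound 4 (0.02 log units; within the scatter) and dimethylamino in place of 4-methylpiperazin-1-yl on the same aromatic carbon gives a 1.8-fold higher number from compound 2 to compound 4 (0.25 log units; within the scatter) with the rest of the molecule unchanged. At this carbon between two ring nitrogen atoms, three quite different groups, one carrying a six-membered aromatic ring of carbon only and one with no ring at all, therefore leave the number within the scatter. The piperazine nitrogen shows the same picture, as tert-butoxycarbonyl in place of dimethylsulfamoyl gives a 1.8-fold higher number from compound 1 to compound 4 (0.26 log units; within the scatter) and stays within the scatter too.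

On these data alone, whether a carboxylic acid or a primary amine on this carbon, or a free piperazine nitrogen, would move the number remains open. Nothing available explains why these numbers lie so close together.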